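From a Large Ring to a Single Fluorine

The compounds below may be only part of what the source reports. "The series", "measured", "known", "first", "only" and "open" are said of these compounds alone.

Of the compounds shown here, three have been measured in an assay on a protein complex for inhibition of CDK8/Cyclin C (Homo sapiens), with a stated time of 1 h, tested at 10 uM; a higher number here means more inhibition at the concentration tested (going by the name of the read-out), a lower number less inhibition. Compound 1 `O=C(/C=C/c1ccncc1-c1ccc2cccnc2c1)N1CCOCC1` gives 33%, compound 2 `O=C(O)/C=C/c1ccncc1-c1ccc2ccccc2c1` gives 102%, and compound 3 `CN1CCN(c2ccc(Nc3cnccc3/C=C/C(N)=O)cc2)CC1` gives 75%. Compound 3 thus stands second of the three: compound 2 lies higher by a margin beyond the usual scatter, while compound 1 lies lower by a margin also beyond that scatter. Compound 4 `NC(=O)/C=C/c1ccncc1Nc1ccc(F)cc1` has not yet been measured in this assay; it differs from compound 3 by fluoro in place of 4-methylpiperazin-1-yl on an aromatic carbon. Among the measured compounds shown here, no step between two measured compounds isolates a change of this kind, so the expectation rests only on compound 3 and its 75%. A decrease beyond the scatter is expected for compound 4, a step of a number 20 percentage points lower from compound 3 to compound 4 (beyond the scatter). Compound 4 is therefore estimated at 55%, with a range from 25% to 85%.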

Compound 4, a percentage reported as inhibition, at one concentration (the size of the read-out at that concentration, not a potency): 70%
Compound 4: middle estimate off by 15 percentage points, on the low side, within the range that was stated.
By their numbers in this assay, from the lowest: compound 1; then compounds 4 and 3 (each within the scatter of the next); then compound 2.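

In this assay the exchange of 4-methylpiperazin-1-yl for fluoro on this aromatic carbon gives a number 5 percentage points lower from compound 3 to compound 4 (within the scatter) and so leaves the read-out within the scatter. In this pair, then, the six-membered non-aromatic ring with its two hetero atoms is not required for the inhibition seen at this concentration, and a single fluorine atom serves as well. Nothing available explains why this is so.

Among the compounds shown here, only this one pair speaks to the position. On these data alone, whether an amine, a methoxy group or plain hydrogen would read alike here stays open.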